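Compound 3 to compound 4: one hydroxy group fewer

This account rests on a few compounds, and the source may have more. Where it says the series, first, only, none or still open, it means among the compounds named here.

Three compounds share one core and differ in the aryl group on the double-bonded chain carbon. In a functional assay on MCF7 cells (Homo sapiens) for cytotoxicity, read by MTT assay, with a stated time of 48 h (a lower number here means a stronger inhibitor, a higher number a weaker inhibitor), compound 1 `COc1ccc(/C=C2/S/C(=N/c3ccccc3)N(Cc3ccncc3)C2=O)cc1` gives 31500 nM and compound 2 `CC(C)c1ccc(/C=C2/S/C(=N/c3ccccc3)N(Cc3ccncc3)C2=O)cc1` gives 53300 nM with a 1.7-fold higher number from compound 1 to compound 2 (0.23 log units; within the scatter) as the step between them. Compound 3 `O=C1/C(=C\c2ccc(O)c(O)c2)S/C(=N/c2ccccc2)N1Cc1ccncc1` gives 12400 nM and stands lowest of the three, with a 2.5-fold lower number from compound 1 to compound 3 (0.40 log units; beyond the scatter) and a 4.3-fold lower number from compound 2 to compound 3 (0.63 log units; beyond the scatter) as its two modest steps.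

Compound 4 `O=C1/C(=C\c2cccc(O)c2)S/C(=N/c2ccccc2)N1Cc1ccncc1` differs by hydrogen in place of hydroxy on an aromatic carbon in one place: hydrogen in place of hydroxy on an aromatic carbon, read further out as 3,4-dihydroxyphenyl to 3-hydroxyphenyl. Among the measured compounds shown here, no measured step removes a single hydroxy group. The two steps into compound 3 replace the whole aryl group, so they bear on this change only loosely. Even the larger, a 4.3-fold lower number from compound 2 to compound 3 (0.63 log units; beyond the scatter) is modest, so only part of it is expected to be lost here. The expected step is a 1.8-fold higher number from compound 3 to compound 4 (0.25 log units; within the scatter) toward a higher number, with little or nothing beyond the scatter. Compound 4 is estimated at 22000 nM with an expected range from 11000 nM to 45000 nM on this estimate.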

Compound 4, half-maximal inhibitory concentration: 43600 nM
The estimate for compound 4 lay 2.0-fold (0.30 log units) below the measured number, within the range that was stated.
By their numbers in this assay, from the lowest: compound 3; then compounds 1, 4 and 2 (each within the scatter of the next).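

In this assay, hydrogen in place of the hydroxy group that sits ortho to a hydroxy group and para to a large group is a change beyond the scatter (a 3.5-fold higher number from compound 3 to compound 4 (0.55 log units; beyond the scatter)), so this single hydroxy group accounts for a measurable part of the low number of compound 3. The remaining hydroxy group does not keep that advantage: compound 4 stays within the scatter of both compound 2 (a 1.2-fold lower number from compound 2 to compound 4 (0.09 log units; within the scatter)) and compound 1 (a 1.4-fold higher number from compound 1 to compound 4 (0.14 log units; within the scatter)). Among these four compounds, only the 3,4-dihydroxyphenyl group stands apart, and no evidence is available to explain that difference.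

The compounds shown leave open whether the hydroxy group at this place could be replaced by an amine or a fluorine atom with the number held. They also leave open how a 4-hydroxyphenyl group would compare, with the other hydroxy group as the one that stays.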